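The source may report more compounds than this note shows. Statements on the series, on what has been measured and on what is new or still open speak of the compounds shown alone.

Working notes on the series.

For the measured compounds named here, compound 2 `COc1cc(-c2nn(-c3cccc(NC(=O)c4cccc(C(F)(F)F)c4)c3)cc2-c2ccncc2)ccc1Cl` gives 1390 nM in a functional assay on HT-29 cells (Homo sapiens) for inhibition, read by sulforhodamine B assay, with a stated time of 48 h (on this read-out lower numbers stand for stronger inhibition of growth and higher numbers for weaker inhibition of growth), the lower of the two numbers measured so far. Compound 1 `O=C(Nc1cccc(-n2cc(-c3ccncc3)c(-c3ccc(Cl)c(O)c3)n2)c1)Nc1cccc(C(F)(F)F)c1` gives 9820 nM in this assay; compound 1 differs from compound 2 in more than one place, so the gap between the two, which lies beyond the scatter, cannot be assigned to a single change.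

Compound 3 `COc1cc(-c2nn(-c3cccc(NC(=O)Nc4cccc(C(F)(F)F)c4)c3)cc2-c2ccncc2)ccc1Cl` is not yet measured. It differs from compound 2 in one place: (3-(trifluoromethyl)phenyl)amino in place of 3-(trifluoromethyl)phenyl on a carbonyl carbon. The carbonyl thereby becomes part of a urea rather than an amide, the same linker class that compound 1 carries. Going by the values given here, no step between measured compounds covers this change alone, so the direction is taken only from the contrast between compound 1 and compound 2, which also carry different substituents on the phenyl ring attached to the shared core.

The growth inhibition concentration of compound 3 in this assay is expected to sit somewhat higher than that of compound 2, a step of a 2.2-fold higher number from compound 2 to compound 3 (0.33 log units; beyond the scatter), with wide uncertainty. The estimate for compound 3 is 3000 nM, in the range 800 nM to 12000 nM.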

Compound 3, concentration for 50% growth inhibition: 748 nM
Compound 3: middle estimate off by 4.0-fold (0.60 log units), on the high side, and the stated range ends above it.
By their numbers in this assay, from the lowest: compounds 3 and 2 (each within the scatter of the next); then compound 1.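

At the carbonyl carbon, (3-(trifluoromethyl)phenyl)amino in place of 3-(trifluoromethyl)phenyl gives a 1.9-fold lower number from compound 2 to compound 3 (0.27 log units; within the scatter) in this assay, so this read-out does not separate the urea from the amide at this position, even though the entering group brings one hydrogen-bond donor. For the compounds shown here, the urea linker is now held constant in a single-place comparison, and methyl in place of hydrogen on an oxygen on an aromatic ring gives a 13-fold lower number from compound 1 to compound 3 (1.12 log units; beyond the scatter), a large step that the earlier compounds could not assign to one change. Going by these compounds alone, of the two changes read here, only the one on the oxygen moves the number beyond the scatter. Nothing at hand bears on the reason for either step.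

Whether the methyl on that oxygen gives a step of similar size with the amide linker remains open, as the compounds shown offer only the urea pair for that comparison. Also open, from the compounds shown here alone, is how a longer chain such as ethyl on the same oxygen, or an amine in place of the oxygen, would read in this assay on the shared core.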